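Moving a methoxy group around the aryl ether of a solubility series

The source may report more compounds than this note shows. Statements on the series, on what has been measured and on what is new or still open speak of the compounds shown alone.

Measured compounds:
- compound 1, `Fc1ccc(Oc2ccc3c(NCCCNCc4ccco4)ccnc3c2)cc1`: 14500 nM
- compound 2, `COc1ccccc1Oc1ccc2c(NCCCNCc3ccco3)ccnc2c1`: 14500 nM

Compound 1 and compound 2 share a core and differ only in the aryl group on the ether oxygen. In a physicochemical assay for solubility, with a stated time of 18 h, at pH 7.4 (on this read-out higher numbers stand for higher solubility and lower numbers for lower solubility), compound 1 gives 14500 nM. In this assay compound 2 gives 14500 nM, so compound 2 stands level with compound 1 at the digits shown; the step of no change at the digits printed from compound 1 to compound 2 (within the scatter) lies within the scatter of the method.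

Compound 3, `COc1ccc(Oc2ccc3c(NCCCNCc4ccco4)ccnc3c2)cc1`, has not yet been measured. Its difference from compound 2 is 4-methoxyphenyl in place of 2-methoxyphenyl on an oxygen on an aromatic ring. Among the measured compounds shown here, no measured step covers this particular rearrangement, so the one step that bears on it only indirectly is no change at the digits printed from compound 1 to compound 2 (within the scatter), where a different swap of the aryl group on the same oxygen left the read-out unchanged. The change from compound 2 to compound 3 is smaller still in kind, since the same atoms are merely joined differently. The expectation is therefore a step of a 1.2-fold lower number from compound 2 to compound 3 (0.08 log units; within the scatter) in this assay, that is, none beyond the scatter. For compound 3 the estimated value in this assay is 12000 nM, with an expected range from 5000 nM to 30000 nM.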

Compound 3, solubility: 14500 nM
Beside the measured number, compound 3's estimate is 1.2-fold (0.08 log units) below it; the measured number falls inside the stated range.
By their numbers in this assay, from the lowest: compounds 1, 2 and 3 (each within the scatter of the next).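

In this assay, among the compounds shown here, compound 2 and compound 3 contain the same atoms, so this pair offers the first look at where the methoxy group sits on the aryl ring: 4-methoxyphenyl in place of 2-methoxyphenyl on an oxygen on an aromatic ring gives no change at the digits printed from compound 2 to compound 3 (within the scatter) in the read-out. The new pair of compound 1 and compound 3 isolates a second kind of change on that ring, methoxy in place of fluoro on an aromatic carbon, and it gives no change at the digits printed from compound 1 to compound 3 (within the scatter) as well. Taken together, these steps show that in these three compounds neither the placing of the methoxy group nor the choice between methoxy and fluoro separates the numbers, and no compound among the three goes against this.

Going by these compounds, whether a more different group on the same aryl ring, such as an amine or a carboxylic acid, would separate the numbers remains open, as does the effect of any change to the shared core. The data shown include no measurement that could explain why these three numbers agree.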